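Sulfonamide in place of the acetylated benzylamine

The source may report more compounds than this note shows. Statements on the series, on what has been measured and on what is new or still open speak of the compounds shown alone.

In a functional assay (aorta) for antagonist activity, with Oryctolagus cuniculus as the target (on this read-out higher numbers stand for weaker inhibition and lower numbers for stronger inhibition), compound 1 `CCCCNC(=O)NCc1ccc(CCCC)n(Cc2ccc(-c3ccccc3-c3nn[nH]n3)cc2)c1=O` gives 10 nM, and compound 2 `CCCCc1ccc(CN(Cc2ccccc2)C(C)=O)c(=O)n1Cc1ccc(-c2ccccc2-c2nn[nH]n2)cc1` gives 1 nM. For the measured compounds named here, compound 2 thus holds the lowest of the two numbers, with compound 1 as its only neighbour. Going by the values given here, the single measured step, a 10-fold lower number from compound 1 to compound 2 (1.00 log units; beyond the scatter), came from a change at the same place as the one now considered. Compound 3 `CCCCc1ccc(CNS(=O)(=O)c2ccccc2)c(=O)n1Cc1ccc(-c2ccccc2-c2nn[nH]n2)cc1` differs from compound 2 by (phenylsulfonyl)amino in place of acetyl(benzyl)amino on a saturated chain carbon bound to an aromatic carbon. Among the compounds with values here, no measured step shows this exchange; the only evidence, a 10-fold lower number from compound 1 to compound 2 (1.00 log units; beyond the scatter), says that this position tolerates substantial change in what is attached, and that such change shifted this assay by a modest amount. With nothing that points in either direction, and the loss of the acetyl and benzyl parts untested, a moderate rise in the number is expected for compound 3, as a step of a 5.0-fold higher number from compound 2 to compound 3 (0.70 log units; beyond the scatter). Compound 3 is therefore estimated at 5 nM, within 1 nM to 30 nM.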

Compound 3, half-maximal inhibitory concentration: 7 nM
Compound 3: middle estimate off by 1.4-fold (0.15 log units), on the low side, within the range that was stated.
By their numbers in this assay, from the lowest: compound 2; then compounds 3 and 1 (each within the scatter of the next).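

In this assay, the exchange gives a 7.0-fold higher number from compound 2 to compound 3 (0.85 log units; beyond the scatter), so an uncharged group with a sulfonyl in place of the acetyl(benzyl)amino does not keep the low number of compound 2. Changing the group on the amine nitrogen in the other direction gives a 1.4-fold lower number from compound 1 to compound 3 (0.15 log units; within the scatter), so phenylsulfonyl and butylcarbamoyl cannot be told apart at this place. Of the three groups seen here, only acetyl(benzyl)amino stands apart beyond the scatter from the other two, and nothing available offers an explanation for this.

The compounds shown leave open whether the benzyl or the acetyl part accounts for the low number of compound 2. A plain acetylamino group, or a benzyl added to the nitrogen of the (phenylsulfonyl)amino group, would separate the two.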